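The source may hold more compounds than are shown below. What is called first, only, known or untested is meant among the compounds shown, and "the series" means these compounds.

Compound 1, `CC[C@@H]1C(=O)N(C)c2cnc(-n3ccc4cc(F)ccc43)nc2N1C1CCCC1`, carries the highest number of the three compounds that have been measured. In a functional assay on Huh-7 cells (Homo sapiens) for antiproliferative activity, read by CCK-8 assay, with a stated time of 72 h (a lower number here means a stronger inhibitor of growth, a higher number a weaker inhibitor of growth), compound 1 gives 16000 nM. Compound 3, `CCC1C(=O)N(C)c2cnc(Nc3ccc(S(=O)(=O)NCC(C)C)cc3)nc2N1c1ccn(C)n1`, gives 8520 nM in this assay, a number that lies within the scatter of the value for compound 1, so the two cannot be told apart. Compound 2, `CC[C@@H]1C(=O)N(C)c2cnc(Nc3ccc(S(=O)(=O)NCCO)cc3)nc2N1C1CCCC1`, gives 278 nM in this assay, a value far below that of compound 1 and clearly beyond the scatter. Going by the values given here, none of the three measured compounds differs from another in only one place, so no measured step speaks directly to the change considered next.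

Compound 4, `CC[C@@H]1C(=O)N(C)c2cnc(-n3ccc4cc(C(=O)NC)ccc43)nc2N1C1CCCC1`, is derived from compound 1 by one exchange: methylcarbamoyl in place of fluoro on an aromatic carbon. Among the compounds with values here, no measured pair shows this exchange, so its effect can only be guessed from compound 1 itself. The step from compound 1 to compound 4 in this assay is expected to stay within the scatter, or to shift the number only modestly downward, and the estimated step is a 2.0-fold lower number from compound 1 to compound 4 (0.30 log units; within the scatter). Compound 4 is therefore expected to give about 8000 nM in this assay, with a range from 2000 nM to 30000 nM.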

Compound 4, concentration for 50% growth inhibition: 842 nM
For compound 4 the middle estimate is 9.5-fold (0.98 log units) above the measured one; measured number outside the range, below it.
By their numbers in this assay, from the lowest: compound 2; then compound 4; then compounds 3 and 1 (each within the scatter of the next).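

In this assay, going by these compounds alone, methylcarbamoyl in place of fluoro on this aromatic carbon gives a 19-fold lower number from compound 1 to compound 4 (1.28 log units; beyond the scatter), the first measured step between two compounds that differ in one place, and it lies beyond the scatter. It shows that the number responds strongly to what sits at this position on the six-membered aromatic ring of carbon only: a single fluorine leaves, 4 heavy atoms enter with a hydrogen-bond donor and a hydrogen-bond acceptor, and the number falls by a large step while the rest of the molecule stays the same. No measurement offered here accounts for the size of this step, so it stands as an observation without an established cause.

The compounds shown leave open which part of the methylcarbamoyl group matters, a question on which a primary carboxamide, a dimethylamide lacking the amide hydrogen, a carboxylic acid or a longer chain on the amide nitrogen at the same aromatic carbon would each bear. They also leave open whether an exchange at this position would give a step of similar size with different groups elsewhere on the shared core.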